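The source may hold more compounds than are shown below. What is called first, only, known or untested is meant among the compounds shown, and "the series" means these compounds.

Measured so far in a functional assay on NCI-H226 cells (Homo sapiens) for inhibition, read by sulforhodamine B assay, with a stated time of 48 h; on this read-out lower numbers stand for stronger inhibition of growth and higher numbers for weaker inhibition of growth:

compound 1 `COc1cc(-c2nn(-c3cccc(NC(=O)Nc4cc(C(F)(F)F)cc(C(F)(F)F)c4)c3)cc2-c2ccncc2)ccc1Cl` gives 21800 nM
compound 2 `COc1cc(-c2nn(-c3cccc(NC(=O)Nc4ccc(Cl)c(Cl)c4)c3)cc2-c2ccncc2)ccc1Cl` gives only a limit, > 50000 nM
compound 3 `O=C(Nc1cccc(-n2cc(-c3ccncc3)c(-c3ccc(Cl)c(O)c3)n2)c1)Nc1ccc(Cl)c(Cl)c1` gives only a limit, > 32500 nM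

Compound 2 stands at a limit of this assay, (the limit of > 50000 nM in this assay, at which 1 of the 3 values shown sits), and no number sits beside it; compound 3 likewise sits at a limit, (the limit of > 32500 nM in this assay, at which 1 of the 3 values shown sits). Within the data shown here, the single step with one change, a step that the two limits leave unreadable from compound 2 to compound 3, therefore carries no readable size. Among the measured compounds shown here, compound 1 is the only compound of the three with a number in this assay.

Compound 4 `COc1cc(-c2nn(-c3cccc(NC(=O)c4ccc(Cl)c(C(F)(F)F)c4)c3)cc2-c2ccncc2)ccc1Cl` differs from compound 2 in one place: 4-chloro-3-(trifluoromethyl)phenyl in place of (3,4-dichlorophenyl)amino on a carbonyl carbon. For the measured compounds named here, no measured step touches this change, and the step from compound 2 to compound 3 gives no size to lean on. Going by the values given here, compound 1, which carries trifluoromethyl groups, sits at 21800 nM in this assay, and that is the only number; it is taken as the rough level for the series as a whole.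

Compound 4 is expected to land near the weak end of the series, with a fair chance of coming back as a limit, estimated at 35000 nM (range 12000 nM to 80000 nM). The implied step, an at least 1.4-fold lower number from compound 2 to compound 4 (0.15 log units; that floor lies within the scatter), is an expectation only, since compound 2 itself has no number.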

Compound 4, concentration for total growth inhibition: > 32500 nM
Compound 4 ended at the assay's limit (the forecaster's own chance of this, stated with the estimate: 45%); the middle value is on the limit's open side.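

Compound 2 and compound 4 both stand at limits in this assay, and the step between them cannot be read. Still open, going by these compounds, is whether 4-chloro-3-(trifluoromethyl)phenyl in place of (3,4-dichlorophenyl)amino on a carbonyl carbon changes growth inhibition at all, and in which direction.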